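A few compounds are considered here, and "the series" means these few. Any claim that something is new, unique, unknown or untested is made for them only; others in the source may bear on it.

Measured in a functional assay on HT-1080 cells (Homo sapiens) for antiproliferative activity, read by MTT assay, with a stated time of 72 h; on this read-out lower numbers stand for stronger inhibition and higher numbers for weaker inhibition:
- Compound 1 `CCOC(=O)c1cc(-c2ccc(OC)c(OCc3ccccc3)c2)c(-c2cc(OC)c(OC)c(OC)c2)s1`: > 100000 nM, a limit and not a number
- Compound 2 `COc1ccc(-c2cc(C(=O)O)sc2-c2cc(OC)c(OC)c(OC)c2)cc1`: 5810 nM
- Compound 3 `COc1ccc(-c2cc(C(=O)O)sc2-c2cc(OC)c(OC)c(OC)c2)cc1[N+](=O)[O-]`: 38100 nM

Compound 3 has the higher of the two true numbers in this assay, so it is the weaker of that pair. Its nearest neighbour is compound 2, and the two differ only by a nitro group in place of hydrogen. That change gives a 6.6-fold higher number from compound 2 to compound 3 (0.82 log units; beyond the scatter).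

Compound 4 `COc1ccc(-c2cc(C(=O)O)sc2-c2cc(OC)c(OC)c(OC)c2)cc1OCc1ccccc1` keeps the acid of compound 3 but carries benzyloxy in place of nitro (benzyloxy in place of nitro on an aromatic carbon). The new group sits on an aromatic carbon, ortho to a methoxy group and meta to a large group.

Within the data shown here, only one measured step bears directly on this place, and it shows that nitro costs activity relative to hydrogen. Losing nitro could therefore recover a little, but the effect of benzyloxy on an acid has not been measured. Compound 1 also carries benzyloxy, but as an ester rather than an acid, so it is a weak guide.

A small move toward lower numbers is expected, with no step beyond the scatter. The expected change is a 1.9-fold lower number from compound 3 to compound 4 (0.28 log units; within the scatter). For compound 4 the estimated value is 20000 nM, within an expected range of 5000 nM to 80000 nM.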

Compound 4, half-maximal inhibitory concentration: > 100000 nM
Compound 4: no number, only a limit; the forecaster's own chance of this, stated with the estimate: 20%; middle value at least 5.0-fold (0.69 log units) away from the limit.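

In this assay, compound 4 gives > 100000 nM, which is a limit and not a number, so the free acid does not keep a measurable value once benzyloxy sits on this aromatic carbon. Replacing nitro with benzyloxy gives an at least 2.6-fold higher number from compound 3 to compound 4 (0.41 log units; beyond the scatter), and benzyloxy in place of hydrogen gives an at least 17-fold higher number from compound 2 to compound 4 (1.23 log units; beyond the scatter), so among the three groups shown at this place, hydrogen gives the strongest inhibition, nitro comes next and benzyloxy gives the weakest. The step between the ethyl ester and the acid cannot be read, since both of its ends are limits, and both benzyloxy compounds now sit at the same ceiling: the limit of > 100000 nM in this assay, at which 2 of the 4 values shown sit.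

Going by these compounds, how far compound 4 lies past its limit remains unknown, so the true size of both readable steps stays open, as does any effect of the acid when benzyloxy is present. On these data alone, it also remains open where a hydroxyl group or an amine on this aromatic carbon would fall relative to hydrogen, nitro and benzyloxy.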